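From 4-cyanophenyl to ethylamino on the shared core

The source may report more compounds than this note shows. Statements on the series, on what has been measured and on what is new or still open speak of the compounds shown alone.

For the measured compounds named here, in an ADME assay on microsomes from liver (Homo sapiens) for metabolic stability, read by LC-MS, with a stated time of 30 min, tested at 1 uM (a higher number here means faster removal of the compound, a lower number slower removal), compound 2 `C[C@@H](c1c[nH]c2ncccc12)c1nnc2ccc(-c3ccc(C#N)cc3)nn12` gives 28 mL.min-1.g-1, the only exact number available so far. Compound 1 `C[C@@H](c1c[nH]c2ncccc12)c1nnc2ccc(-c3cnn(C)c3)nn12` gives < 7.6 mL.min-1.g-1, which is a limit of the assay and not a number. Compound 3 `CCNc1ccc2nnc([C@@H](C)c3c[nH]c4ncccc34)n2n1` has not yet been measured. Its structure differs at one place: ethylamino in place of 4-cyanophenyl on an aromatic carbon. In words, ethylamino stands in place of 4-cyanophenyl on an aromatic carbon.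

Going by the values given here, only one measured step bears on this place: an at least 3.6-fold higher number from compound 1 to compound 2 (0.56 log units; beyond the scatter), which lies beyond the scatter. Read in reverse, that step suggests that losing 4-cyanophenyl may lower the number, though its replacement there was a different group, so the guide is loose. A modest fall in this assay is therefore expected, with an estimated 2.5-fold lower number from compound 2 to compound 3 (0.41 log units; beyond the scatter). For compound 3, the estimate is 11 mL.min-1.g-1, with an expected range from 5 mL.min-1.g-1 to 26 mL.min-1.g-1.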

Compound 3, intrinsic clearance in microsomes: 18 mL.min-1.g-1
The estimate for compound 3 lay 1.6-fold (0.21 log units) below the measured number; low and high end bracket the measured number.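

In this assay, ethylamino in place of 4-cyanophenyl gives a 1.6-fold lower number from compound 2 to compound 3 (0.19 log units; within the scatter), so at this aromatic carbon an open chain without a ring and the larger aromatic group cannot be told apart. The other comparison, with ethylamino in place of 1-methyl-1H-pyrazol-4-yl, gives an at least 2.3-fold higher number from compound 1 to compound 3 (0.37 log units; beyond the scatter), which shows that the higher number seen earlier does not depend on a six-membered aromatic ring of carbon only, and leaves the 1-methyl-1H-pyrazol-4-yl group apart from the other two. The value of compound 1 is a limit of the assay and not a number: the limit of < 7.6 mL.min-1.g-1 in this assay, at which 1 of the 3 values shown sits.

The compounds shown leave open whether a longer chain, such as butylamino, would stay level with ethylamino at this place. They also leave open how a dimethylamino group, which lacks the amine hydrogen, or an ether oxygen in place of the amine nitrogen would read.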